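Squaramide-type series: phenyl in place of sulfamoyl

This account rests on a few compounds, and the source may have more. Where it says the series, first, only, none or still open, it means among the compounds named here.

Measured in a functional assay for inhibition, with Rattus norvegicus as the target; a higher number here means a weaker inhibitor, a lower number a stronger inhibitor:
- compound 1 `CC(/N=c1\c(O)c(O)\c1=N/c1cccnc1)C(C)(C)C` gives 1950 nM
- compound 2 `CC(/N=c1\c(O)c(O)\c1=N/c1ccc(S(N)(=O)=O)cc1)C(C)(C)C` gives > 30000 nM as a limit

Compound 2 gives > 30000 nM as a limit of the assay and not as a number. Within the data shown here, it is the only compound of the pair held at such a limit, as the record shows (the limit of > 30000 nM in this assay, at which 1 of the 2 values shown sits) for this series. Compound 1 gives 1950 nM in this assay as a true number.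

Compound 3 (`CC(/N=c1\c(O)c(O)\c1=N/c1ccc(-c2ccccc2)cc1)C(C)(C)C`) carries phenyl in place of sulfamoyl on an aromatic carbon, para to a large group (phenyl in place of sulfamoyl on an aromatic carbon) on the ring that compound 2 also carries. Among the measured compounds shown here, no measured pair isolates this change, so the size of the step is poorly constrained. Compound 1 at 1950 nM shows that the shared core can give a number in this assay, so a move towards a lower number, and thus a stronger inhibitor, is expected. It remains possible that compound 3 also gives no number. The expected change is an at least 5.0-fold lower number from compound 2 to compound 3 (0.69 log units; beyond the scatter) in this estimate. Compound 3 is expected at 6000 nM in this assay, with an estimated range from 1000 nM to 30000 nM around that figure.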

Compound 3, half-maximal inhibitory concentration: > 30000 nM
Compound 3 gave a limit, no number (the forecaster's own chance of this, stated with the estimate: 30%); at least 5.0-fold (0.69 log units) between middle value and limit.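

In this assay compound 3 gives > 30000 nM, which is a limit and not a number. Compound 2 sits at a limit as well, so no step can be read between compound 2 and compound 3: the limit of > 30000 nM in this assay, at which 2 of the 3 values shown sit.

The compounds shown leave open whether phenyl in place of sulfamoyl on an aromatic carbon changes the read-out in this assay at all.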